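Aryl swap on the sulfonyl sulfur, first unmeasured step

The source may report more compounds than this note shows. Statements on the series, on what has been measured and on what is new or still open speak of the compounds shown alone.

Two compounds of this series have numbers in an assay on isolated protein for displacement of a labelled ligand from metabotropic glutamate receptor 5 (Homo sapiens), with a stated time of 60 min, tested at 1 uM (a lower number here means less inhibition, a higher number more inhibition at the concentration tested (going by the name of the read-out)), so far. Compound 1 `Cc1ccc(S(=O)(=O)c2cnc3cc(F)ccc3c2N2CCC(C)CC2)cc1C` gives 90% in this assay. Compound 2 `COc1ccc(S(=O)(=O)c2cnc3ccc(C)cc3c2N2CCC(C)CC2)cc1Cl` gives 93% in this assay. The two numbers lie within the usual scatter of one another, so compound 1 stands level with compound 2; both numbers read high at the concentration tested, and neither number can be called the higher. Compound 3 `CC1CCN(c2c(S(=O)(=O)c3ccc(Cl)c(Cl)c3)cnc3cc(F)ccc23)CC1` has not yet been measured. It differs from compound 1 by 3,4-dichlorophenyl in place of 3,4-dimethylphenyl on a sulfonyl sulfur. Among the compounds with values here, no step between measured compounds bears on this change, and with both values at hand already high there is little room upward. The expected step is a number 3 percentage points lower from compound 1 to compound 3 (within the scatter), a size that does not exceed the scatter. Compound 3 is therefore estimated to give about 87% in this assay, with a range from 68% to 97%.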

Compound 3, a percentage reported as inhibition, at one concentration (the size of the read-out at that concentration, not a potency): 94%
The estimate for compound 3 lay 7 percentage points below the measured number; measured number inside the range.
By their numbers in this assay, from the lowest: compounds 1, 2 and 3 (each within the scatter of the next).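

In this assay, 3,4-dichlorophenyl in place of 3,4-dimethylphenyl on a sulfonyl sulfur gives a number 4 percentage points higher from compound 1 to compound 3 (within the scatter). Within the data shown here, this is the first reading at this position with the rest of the molecule held constant, and it separates the two aryl groups by no more than the scatter, so at this concentration the sulfonyl sulfur accepts either group on the core of compound 1. The read-out is a single-concentration number and not a potency, so the pair does not rank the two groups, and no measurement at hand bears on a reason for this result.

Still open, from the compounds shown here alone, is whether the read-out holds with unsubstituted phenyl, or with a ring of another kind such as cyclohexyl, on the sulfonyl sulfur. Equally open, going by these compounds, is whether a phenyl ring carrying a carboxylic acid or an amine keeps it.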